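The source may report more compounds than this note shows. Statements on the series, on what has been measured and on what is new or still open speak of the compounds shown alone.

Of the compounds shown here, three built on one shared core have been tested in a functional assay on A549 cells (Homo sapiens) for antiproliferative activity, read by MTT assay, with a stated time of 48 h; a lower number here means a stronger inhibitor, a higher number a weaker inhibitor. Compound 1 `CCN(CC)CCCCOc1c(OCc2ccccc2)cc2oc(-c3ccccc3)cc(=O)c2c1O` gives 1800 nM. Compound 2 `O=c1cc(-c2ccccc2)oc2cc(O)c(OCCCN3CCCC3)c(O)c12` reaches only the limit of the assay, > 100000 nM, so no number is known for it. Compound 3 `COc1cc2oc(-c3ccccc3)cc(=O)c2c(O)c1OCCCN1CCN(C)CC1` gives 18000 nM, the highest of the two numbers recorded, with compound 1 sitting at a lower number, a gap beyond the usual scatter. Compound 4 `COc1cc2oc(-c3ccccc3)cc(=O)c2c(O)c1OCCCCN1CCCC1` is the next compound to be measured. It differs from compound 3 in one place: (pyrrolidin-1-yl)methyl in place of 4-methylpiperazin-1-yl on a saturated chain carbon, three bonds along the chain from an oxygen on an aromatic ring. Among the compounds with values here, no two measured compounds differ in this way alone, so the step is judged from the structures. For compound 4 the expectation is a modest step to a lower number, a 2.0-fold lower number from compound 3 to compound 4 (0.30 log units; within the scatter), giving an estimate of 9000 nM, most likely between 3000 nM and 30000 nM.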

Compound 4, half-maximal inhibitory concentration: 13000 nM
Beside the measured number, compound 4's estimate is 1.4-fold (0.16 log units) below it; measured number inside the range.
By their numbers in this assay, from the lowest: compound 1; then compounds 4 and 3 (each within the scatter of the next). At a limit, above all of these: compound 2.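

Putting (pyrrolidin-1-yl)methyl in place of 4-methylpiperazin-1-yl, on a saturated chain carbon, three bonds along the chain from an oxygen on an aromatic ring, gives a 1.4-fold lower number from compound 3 to compound 4 (0.14 log units; within the scatter) in this assay. Within the data shown here, this is the only step that can be read so far. For this pair, swapping a six-membered ring with two nitrogens for a five-membered ring with one leaves no change that stands clear of the scatter.

Nothing measured here bears on why the two compounds read alike. From the compounds shown here alone, whether a piperidine or a morpholine in the same place would give a different number remains open.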